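The compounds below may be only part of what the source reports. "The series", "measured", "known", "first", "only" and "open" are said of these compounds alone.

Compounds measured so far:
compound 1 `Cn1c(=O)c(S(=O)(=O)c2ccc(F)cc2F)cc2cnc(Nc3ccc4[nH]c(C(=O)O)cc4c3)nc21`: 10000 nM
compound 2 `Cn1c(=O)c(S(=O)(=O)c2ccc(Cl)cc2)cc2cnc(Nc3ccc4[nH]ccc4c3)nc21`: 250 nM
compound 3 `Cn1c(=O)c(S(=O)(=O)c2ccc(F)cc2N)cc2cnc(Nc3ccc4[nH]ccc4c3)nc21`: 3000 nM

In a functional assay on DU-145 cells (Homo sapiens) for inhibition, read by trypan blue exclusion, with a stated time of 72 h (on this read-out higher numbers stand for weaker inhibition and lower numbers for stronger inhibition), compound 1 gives the highest of the three numbers; compound 3 sits nearer to it, and compound 2 furthest away, both with lower numbers beyond the scatter. For the measured compounds named here, the only single-point step among the measured compounds, a 12-fold higher number from compound 2 to compound 3 (1.08 log units; beyond the scatter), concerns the aryl group on the sulfonyl sulfur and not the group on the aromatic amine nitrogen, so it does not bear directly on the change now at hand.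

Compound 4 `Cn1c(=O)c(S(=O)(=O)c2ccc(F)cc2F)cc2cnc(Nc3cnc4[nH]ccc4c3)nc21` differs from compound 1 on that nitrogen: a group of 9 heavy atoms (7 carbon, 2 nitrogen; one five-membered aromatic ring with 1 hetero atom, one six-membered aromatic ring with 1 hetero atom) in place of a group of 12 heavy atoms (9 carbon, 1 nitrogen, 2 oxygen; one five-membered aromatic ring with 1 hetero atom, one six-membered aromatic ring of carbon only), on a nitrogen on an aromatic ring. Going by the values given here, compounds 2 and 3, which carry an indole without the carboxy group at this position, both show lower numbers than compound 1, but they also differ from it on the sulfonyl aryl, so no single step isolates the change. On that basis compound 4 is expected to give a lower number than compound 1, with a 6.7-fold lower number from compound 1 to compound 4 (0.82 log units; beyond the scatter) as the estimated step, though with a wide margin. The estimate for compound 4 is 1500 nM, within 300 nM to 8000 nM.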

Compound 4, half-maximal inhibitory concentration: 750 nM
The estimate for compound 4 lay 2.0-fold (0.30 log units) above the measured number, and the stated range covers the measured number.
By their numbers in this assay, from the lowest: compound 2; then compound 4; then compound 3; then compound 1.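

In this assay, for the compounds shown here, the step of a 13-fold lower number from compound 1 to compound 4 (1.12 log units; beyond the scatter) is the first reading of the group on the aromatic amine nitrogen with the sulfonyl aryl group and the rest of the core held constant, and it shows that this position alone can shift the number beyond the scatter. The change is nonetheless compound: the 2-carboxy-1H-indol-5-yl group loses its carboxy group, while a hetero atom enters the six-membered ring, and the step cannot divide its size between these two differences. Nothing available explains the step.

Which of the two differences carries the step stays open; an indole without the carboxy group on this same sulfonyl aryl group would separate them. Also open, going by these compounds, is how a methyl ester or a primary amide would read in place of the carboxylic acid.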